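Chloro for ethyl on a urea side chain

A few compounds are considered here, and "the series" means these few. Any claim that something is new, unique, unknown or untested is made for them only; others in the source may bear on it.

Measured compounds and their numbers in a functional assay on MCF7 cells (Homo sapiens) for antiproliferative activity, read by sulforhodamine B assay, with a stated time of 48 h; on this read-out lower numbers stand for stronger inhibition and higher numbers for weaker inhibition:
compound 1 `CCCC(=O)Nc1ccc(S(=O)(=O)Oc2ccccc2I)cc1`, 9700 nM
compound 2 `O=C(CCl)Nc1ccc(S(=O)(=O)Oc2ccccc2I)cc1`, 2500 nM
compound 3 `CCCCCNC(=O)Nc1ccc(S(=O)(=O)Oc2ccccc2I)cc1`, 5400 nM

Compound 3 stands second highest of the three numbers in this assay. Its nearest neighbour is compound 1, and a 1.8-fold lower number from compound 1 to compound 3 (0.25 log units; within the scatter) lies within the scatter. Its furthest is compound 2, and a 2.2-fold higher number from compound 2 to compound 3 (0.33 log units; beyond the scatter) counts as a modest step beyond the scatter.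

Compound 4 `O=C(NCCCCl)Nc1ccc(S(=O)(=O)Oc2ccccc2I)cc1` differs from compound 3 by chloro in place of ethyl on a saturated chain carbon, three bonds along the chain from an amide-type nitrogen. The measured step that bears most on this change is a 3.9-fold lower number from compound 1 to compound 2 (0.59 log units; beyond the scatter), where the same exchange of chloro for ethyl sat on a chain carbon bound to the carbonyl carbon and gave a modest gain. For the measured compounds named here, in compound 4 the exchange sits further out along the chain, and no measured pair shows how the gain carries over that distance, so the expectation is for a smaller step in the same direction, one that may not clear the scatter.

Compound 4 is therefore expected to give 3500 nM in this assay, with a range from 1500 nM to 8000 nM, which means an expected step of a 1.5-fold lower number from compound 3 to compound 4 (0.19 log units; within the scatter).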

Compound 4, half-maximal inhibitory concentration: 7600 nM
Compound 4: middle estimate off by 2.2-fold (0.34 log units), on the low side, and the stated range covers the measured number.
By their numbers in this assay, from the lowest: compound 2; then compounds 3, 4 and 1 (each within the scatter of the next).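

In this assay, the exchange of chloro for ethyl does not give the same result at both places, for a 1.4-fold higher number from compound 3 to compound 4 (0.15 log units; within the scatter) and the gain seen on the chain carbon bound to a carbonyl carbon does not reappear three bonds along the chain from an amide-type nitrogen: the same change on two cores in this assay, a 3.9-fold lower number (0.59 log units; beyond the scatter) from compound 1 to compound 2 and a 1.4-fold higher number (0.15 log units; within the scatter) from compound 3 to compound 4, 5.5-fold (0.74 log units) apart, beyond the scatter of two such steps Compound 2 remains apart, with a 3.0-fold higher number from compound 2 to compound 4 (0.48 log units; beyond the scatter), while a 1.3-fold lower number from compound 1 to compound 4 (0.11 log units; within the scatter), so (3-chloropropyl)amino cannot be told from propyl on a carbonyl carbon. A chloro group on the side chain is therefore not enough on its own to give the lower number, and compound 4 stands against any such rule, leaving compound 2 as the only one of these compounds set apart from the others.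

The compounds shown leave open whether the number of compound 2 depends on the position of the chloro group on its chain or on the amide as opposed to the urea. As far as these compounds go, it also remains open how a urea bearing a 2-chloroethyl chain, or a bromo or amino group in place of the chloro at the end of the 3-chloropropyl chain, would stand in this assay.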